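From 4-fluorophenyl to 2-chlorophenyl on a shared core

A few compounds are considered here, and "the series" means these few. Any claim that something is new, unique, unknown or untested is made for them only; others in the source may bear on it.

In a functional assay on HCT-116 cells (Homo sapiens) for antiproliferative activity, with a stated time of 72 h (a higher number here means a weaker inhibitor, a lower number a stronger inhibitor), compound 1 `Nc1ncnn2c([C@@H]3O[C@H](CO)[C@@H](O)[C@H]3O)cc(-c3ccccc3)c12` gives 82600 nM and compound 2 `Nc1ncnn2c([C@@H]3O[C@H](CO)[C@@H](O)[C@H]3O)cc(-c3ccc(F)cc3)c12` gives 42500 nM. Among the measured compounds shown here, these are the only two numbers so far, and they lie within the usual scatter of each other, so compound 2 cannot be ranked apart from compound 1. The next compound, compound 3 `Nc1ncnn2c([C@@H]3O[C@H](CO)[C@@H](O)[C@H]3O)cc(-c3ccccc3Cl)c12`, keeps the shared core but has 2-chlorophenyl in place of 4-fluorophenyl on an aromatic carbon. For the measured compounds named here, no measured compound carries a 2-chlorophenyl group, so the evidence is thin. Going by the values given here, the one measured change on the aryl group, a 1.9-fold lower number from compound 1 to compound 2 (0.29 log units; within the scatter), stayed small, so no step beyond the scatter is expected in this assay. The expected step is a 1.1-fold higher number from compound 2 to compound 3 (0.02 log units; within the scatter). Compound 3 is estimated at 45000 nM, with an expected range of 15000 nM to 100000 nM.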

Compound 3, half-maximal inhibitory concentration: > 100000 nM
Compound 3: only a limit was reported; the forecaster's own chance of this, stated with the estimate: 25%; middle value at least 2.2-fold (0.34 log units) from the limit.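

For compound 3, the assay returned only a limit rather than a number: the limit of > 100000 nM in this assay, at which 1 of the 3 values shown sits. Replacing 4-fluorophenyl with 2-chlorophenyl gives an at least 2.3-fold higher number from compound 2 to compound 3 (0.37 log units; beyond the scatter), so this aryl group can shift the read-out by more than the scatter, which the step from hydrogen to fluoro did not show. The comparison with the unsubstituted phenyl is less informative: it gives an at least 1.2-fold higher number from compound 1 to compound 3 (0.08 log units; that floor lies within the scatter), so chloro in place of hydrogen cannot be said to have changed the result.

The step from compound 2 to compound 3 changes both the halogen and where it sits on the phenyl ring, and the compounds shown cannot separate those two changes. As far as these compounds go, how an amine or a carboxylic acid on that phenyl ring would behave also remains open.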